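Chloro to hydroxy on two cores, all at the limit

This account rests on a few compounds, and the source may have more. Where it says the series, first, only, none or still open, it means among the compounds named here.

Compound 1 `COc1cc(OC)c(-c2cc(=O)c3cc(Cl)ccc3o2)cc1OC` and compound 2 `COc1cc(OC)c(OC)cc1/C=C/C(=O)c1cc(Cl)ccc1O` carry the same trimethoxyphenyl part on different cores; the difference between the two cores is not broken down here. Compound 3 `COc1cc(OC)c(OC)cc1/C=C/C(=O)c1cc(O)ccc1O` is the hydroxy analogue of compound 2. All three have been run in a functional assay on SW982 cells (Homo sapiens) for inhibition, read by MTT assay, with a stated time of 72 h; on this read-out higher numbers stand for weaker inhibition and lower numbers for stronger inhibition. In this assay compound 1 gives > 150000 nM, which is a limit of the assay and not a number. In this assay compound 2 gives > 150000 nM, again only a limit. In this assay compound 3 gives > 150000 nM, also a limit. The change from compound 2 to compound 3 is hydroxy in place of chloro on an aromatic carbon, and it yields a step that the two limits leave unreadable from compound 2 to compound 3. The one firm point so far is the limit of > 150000 nM in this assay, at which 3 of the 3 values shown sit.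

Compound 4 `COc1cc(OC)c(-c2cc(=O)c3cc(O)ccc3o2)cc1OC` awaits measurement in this assay. It carries the same kind of change relative to compound 1: hydroxy in place of chloro on an aromatic carbon. The surroundings are not identical: in compound 3 the hydroxy sits on a six-membered aromatic ring of carbon only, meta to a large group and para to a hydroxy group, whereas in compound 4 it sits on a ring that is part of a fused or bridged system of two rings, meta to a fused ring and para to a fused ring.

The step that the limit leaves unreadable from compound 1 to compound 4 is expected to be small, because a step that the two limits leave unreadable from compound 2 to compound 3 gave no readable movement on the other core. For compound 4 the estimate is 200000 nM, in a range from 80000 nM to 600000 nM, with a strong expectation that the assay again reports only a limit.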

Compound 4, half-maximal inhibitory concentration: > 150000 nM
Compound 4: a limit, no number (the forecaster's own chance of this, stated with the estimate: 85%); the middle value does not contradict the limit.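

No step can be read from compound 1 to compound 4, and hydroxy in place of chloro stays as unreadable there as from compound 2 to compound 3, because every end of both pairs is a limit and not a number: the limit of > 150000 nM in this assay, at which 4 of the 4 values shown sit.

The compounds shown leave open whether hydroxy in place of chloro changes inhibition in this assay on either core, and what number any of the four compounds would give.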